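Does a longer chain move a cytotoxicity limit?

The source may hold more compounds than are shown below. What is called first, only, known or untested is meant among the compounds shown, and "the series" means these compounds.

Measured so far in an ADME assay on Vero cells (Chlorocebus sabaeus) for cytotoxicity; a higher number here means a weaker inhibitor, a lower number a stronger inhibitor:
compound 1 `CCCCCCC(=O)c1cc(O)c(O)c(O)c1`: > 1000 nM (a limit)
compound 2 `CCCCCCCC(=O)c1cc(O)c(O)c(O)c1`: > 1000 nM (a limit)

Neither compound gave an actual number. On these data alone, compound 1 stands at > 1000 nM as a limit, so its true value is unknown. Compound 3 `CCCCCCCCCCCCCCC(=O)c1cc(O)c(O)c(O)c1` keeps the core of compound 1 and differs only in its chain, through octyl in place of hydrogen on a saturated chain carbon, six bonds along the chain from a carbonyl carbon on that chain.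

Among the compounds with values here, the one measured step that bears on this is a step that the two limits leave unreadable from compound 1 to compound 2 and it adds only a methyl. Its size cannot be read because the limit of > 1000 nM in this assay, at which 2 of the 2 values shown sit, covers both compounds. The data therefore give no firm size or direction for the much larger change, though a lower number in this assay remains possible.

For compound 3 the expected value is 1500 nM with an estimated range from 300 nM to 10000 nM as its spread. This amounts to an expected step that the limit leaves unreadable from compound 1 to compound 3 as a rough estimate, and another limit is the likeliest report.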

Compound 3, half-maximal inhibitory concentration: > 1000 nM
Compound 3: only a limit was reported; the forecaster's own chance of this, stated with the estimate: 65%; the middle value does not contradict the limit.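

Compound 3 gives no readable step from compound 1 or compound 2 in this assay, because all three compounds report only a limit and no actual number: the limit of > 1000 nM in this assay, at which 3 of the 3 values shown sit.

The compounds shown leave open where their true values lie and whether chain length changes them at all.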